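This account rests on a few compounds, and the source may have more. Where it says the series, first, only, none or still open, it means among the compounds named here.

Three nucleoside analogues sharing one core differ only in the five-membered ring attached to an aromatic carbon of that core. Compound 1 `OC[C@H]1O[C@@H](n2cc(F)c3c(-c4ccco4)ncnc32)[C@H](O)[C@@H]1O` carries furan-2-yl; in a functional assay on CCRF-CEM cells (Homo sapiens) for cytotoxicity, read by XTT assay, with a stated time of 3 days (on this read-out higher numbers stand for weaker inhibition and lower numbers for stronger inhibition), compound 1 gives 1400 nM. Compound 2 `OC[C@H]1O[C@@H](n2cc(F)c3c(-c4cccs4)ncnc32)[C@H](O)[C@@H]1O` carries thiophen-2-yl, and in this assay compound 2 gives 270 nM. Compound 3 `OC[C@H]1O[C@@H](n2cc(F)c3c(-c4nccs4)ncnc32)[C@H](O)[C@@H]1O` carries 1,3-thiazol-2-yl, and in this assay compound 3 gives 550 nM, the second highest of the three numbers. Exchanging this ring has so far given a 5.2-fold lower number from compound 1 to compound 2 (0.71 log units; beyond the scatter), a 2.5-fold lower number from compound 1 to compound 3 (0.41 log units; beyond the scatter) and a 2.0-fold higher number from compound 2 to compound 3 (0.31 log units; beyond the scatter). Compound 4 `OC[C@H]1O[C@@H](n2cc(F)c3c(-c4c[nH]cn4)ncnc32)[C@H](O)[C@@H]1O` differs from compound 3 by 1H-imidazol-4-yl in place of 1,3-thiazol-2-yl on an aromatic carbon. Going by the values given here, none of the measured steps concerns 1H-imidazol-4-yl, so they bear only loosely on this change; what they show is that swapping the five-membered ring shifts the number modestly, in either direction. On that basis a modest rise in the number is expected, meaning weaker inhibition. Compound 4 is expected to give 2000 nM, within a range from 500 nM to 8000 nM. That estimate corresponds to an expected 3.6-fold higher number from compound 3 to compound 4 (0.56 log units; beyond the scatter).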

Compound 4, half-maximal inhibitory concentration: 1800 nM
Compound 4: middle estimate off by 1.1-fold (0.05 log units), on the high side; the measured number falls inside the stated range.
By their numbers in this assay, from the lowest: compound 2; then compound 3; then compounds 1 and 4 (each within the scatter of the next).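

Placing 1H-imidazol-4-yl on this aromatic carbon gives in this assay a 3.3-fold higher number from compound 3 to compound 4 (0.51 log units; beyond the scatter) and a 6.7-fold higher number from compound 2 to compound 4 (0.82 log units; beyond the scatter) so thiophen-2-yl remains the ring with the lowest number among the four. The change from compound 3 keeps a five-membered aromatic ring with the same count of heavy atoms, yet it replaces sulfur with nitrogen and adds a hydrogen-bond donor, which shows that rings of equal size need not behave alike at this position. The remaining step is a 1.3-fold higher number from compound 1 to compound 4 (0.11 log units; within the scatter) so furan-2-yl and 1H-imidazol-4-yl cannot be told apart here.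

No measurement shown explains why the number rises with 1H-imidazol-4-yl. Also open, on these data alone, is whether an amine or a phenyl ring at this position would give a number on either side of those seen so far.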